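The compounds below may be only part of what the source reports. "The series", "measured", "known", "first", "only" and "open" are said of these compounds alone.

Measured compounds in a functional assay on HMEC-1 cells (Homo sapiens) for antiproliferative activity, read by cell counting, with a stated time of 4 days; a lower number here means a stronger inhibitor, a higher number a weaker inhibitor:
- compound 1, `CC(Nc1ccccc1Oc1ccc(Cl)cc1)=C1C(=O)CC(c2ccccc2)CC1=O`: 260 nM
- compound 2, `COc1ccc(Oc2ccccc2NC(C)=C2C(=O)CC(c3ccccc3)CC2=O)cc1OC`: 140 nM
- compound 3, `CC(Nc1ccccc1Oc1cccc(N)c1)=C1C(=O)CC(c2ccccc2)CC1=O`: 41 nM

Compound 1 carries the highest number of the three; the gap to compound 2, a 1.9-fold lower number from compound 1 to compound 2 (0.27 log units; within the scatter), stays within the scatter, whereas the gap to compound 3, a 6.3-fold lower number from compound 1 to compound 3 (0.80 log units; beyond the scatter), lies beyond it. Between those two, a 3.4-fold lower number from compound 2 to compound 3 (0.53 log units; beyond the scatter) is also beyond the scatter.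

Compound 4, `COc1cccc(Oc2ccccc2NC(C)=C2C(=O)CC(c3ccccc3)CC2=O)c1`, is not yet measured. Its change from compound 1 is 3-methoxyphenyl in place of 4-chlorophenyl on an oxygen on an aromatic ring.

Within the data shown here, two measured steps bear on this: the exchange for 3,4-dimethoxyphenyl at the same place gave a small change, a 1.9-fold lower number from compound 1 to compound 2 (0.27 log units; within the scatter), and the exchange for 3-aminophenyl gave a modest drop, a 6.3-fold lower number from compound 1 to compound 3 (0.80 log units; beyond the scatter). A single methoxy group shares a feature of the 3,4-dimethoxyphenyl entry and the placement of the 3-aminophenyl entry, so a modest lowering of the number is expected, not as large as that seen for compound 3 with 41 nM.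

Compound 4 is therefore estimated at 130 nM, with a range of 50 nM to 350 nM, meaning an expected step of a 2.0-fold lower number from compound 1 to compound 4 (0.30 log units; within the scatter).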

Compound 4, half-maximal inhibitory concentration: 59 nM
Compound 4: the middle estimate sits 2.2-fold (0.34 log units) above what was measured, within the range that was stated.
By their numbers in this assay, from the lowest: compounds 3 and 4 (each within the scatter of the next); then compounds 2 and 1 (each within the scatter of the next).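

In this assay, the step to 3-methoxyphenyl at this oxygen, a 4.4-fold lower number from compound 1 to compound 4 (0.64 log units; beyond the scatter), is beyond the scatter, so an uncharged methoxy entry with no amino group also gives a lower number than 4-chlorophenyl. Methoxy in place of amino stays within the scatter, a 1.4-fold higher number from compound 3 to compound 4 (0.16 log units; within the scatter), while hydrogen in place of the second methoxy of the 3,4-dimethoxyphenyl group, a 2.4-fold lower number from compound 2 to compound 4 (0.38 log units; beyond the scatter), is beyond it, so that added methoxy goes with a higher number here. No measurement at hand accounts for these steps.

The compounds shown do not separate the loss of the chlorine from the change in where the substituent sits, and an unsubstituted phenyl or a chloro group in place of the methoxy would bear on that. On these data alone, how far this position tolerates other groups also stays open, for instance a hydroxy group or a longer ethoxy chain in place of the methoxy.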